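A Methoxy in Place of Bromo on an Aromatic Carbon

The source may hold more compounds than are shown below. What is called first, only, known or untested is meant among the compounds shown, and "the series" means these compounds.

Compound 1 `CC(C)=CCOc1cc(O)c2c(c1)OC(c1cccc(Cl)c1)CC2=O`: 6060 nM
Compound 2 `CC(C)=CCOc1cc(O)c2c(c1)OC(c1ccc(Br)cc1)CC2=O`: 2770 nM

In a functional assay (a higher number here means a weaker inhibitor, a lower number a stronger inhibitor), compound 2 gives 2770 nM, the lower of the two numbers. Compound 3 `COc1ccc(C2CC(=O)c3c(O)cc(OCC=C(C)C)cc3O2)cc1` differs from it by methoxy in place of bromo on an aromatic carbon, the change from 4-bromophenyl to 4-methoxyphenyl. For the measured compounds named here, the only measured step, a 2.2-fold lower number from compound 1 to compound 2 (0.34 log units; beyond the scatter), is modest and came with 4-bromophenyl in place of 3-chlorophenyl. Going by the values given here, no measured compound carries a methoxy, which makes that step a weak guide. A similarly modest move toward a higher number is therefore expected in this assay, with wide uncertainty. The expected change is a 1.6-fold higher number from compound 2 to compound 3 (0.21 log units; within the scatter). For compound 3 the estimated value is 4500 nM, within a range of 1800 nM to 11000 nM.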

Compound 3, half-maximal inhibitory concentration: 5080 nM
Compound 3: middle estimate off by 1.1-fold (0.05 log units), on the low side, within the range that was stated.
By their numbers in this assay, from the lowest: compounds 2, 3 and 1 (each within the scatter of the next, the first and the last beyond it).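

In this assay, methoxy in place of bromo gives a 1.8-fold higher number from compound 2 to compound 3 (0.26 log units; within the scatter), and 4-methoxyphenyl in place of 3-chlorophenyl gives a 1.2-fold lower number from compound 1 to compound 3 (0.08 log units; within the scatter). For the compounds shown here, the position therefore accepts methoxy, the first group here bearing an oxygen, with compound 3 within the scatter of both compound 1 and compound 2, even though those two lie beyond the scatter of each other. Nothing available explains this result. Still open, going by these compounds, is whether an amine or a carboxylic acid on this aromatic carbon would move the number beyond the scatter.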